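The source may hold more compounds than are shown below. What is called first, only, known or untested is meant among the compounds shown, and "the series" means these compounds.

Measured so far in a functional assay on H184B5F5/M10 cells (Homo sapiens) for antiproliferative activity, read by XTT assay, with a stated time of 72 h; a lower number here means a stronger inhibitor, a higher number a weaker inhibitor:
- compound 1 `COc1ccc(-c2cc3ccccc3nc2/C=C/C(=O)c2c(OC)cccc2OC)cc1`: 4470 nM
- compound 2 `COc1ccc(-c2cc3ccccc3nc2/C=C/C(=O)c2ccc(N)cc2)cc1`: 9290 nM
- compound 3 `COc1ccc(-c2cc3ccccc3nc2/C=C/C(=O)c2ccc([N+](=O)[O-])cc2)cc1`: 6100 nM

Compound 3 stands second highest of the three numbers; its nearest neighbour is compound 1, with a 1.4-fold higher number from compound 1 to compound 3 (0.14 log units; within the scatter) lying within the scatter, and its furthest is compound 2, with a 1.5-fold lower number from compound 2 to compound 3 (0.18 log units; within the scatter) also within the scatter. Within the data shown here, the only step beyond the scatter in the set is a 2.1-fold higher number from compound 1 to compound 2 (0.32 log units; beyond the scatter), and that one is modest.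

Compound 4 `COc1ccc(-c2cc3ccccc3nc2/C=C/C(=O)c2cccs2)cc1` differs from compound 3 by thiophen-2-yl in place of 4-nitrophenyl on a carbonyl carbon. All three measured steps bear on it, since each exchanges the group on the same carbonyl carbon; two of them fall within the scatter and the third is modest. The group entering here has not been tried, so the step is taken to be of the same order as those seen: none beyond the scatter expected in this assay, with no direction favoured. The estimated step is a 1.1-fold lower number from compound 3 to compound 4 (0.04 log units; within the scatter). For compound 4 the estimate is 5500 nM, with a range from 2200 nM to 14000 nM.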

Compound 4, half-maximal inhibitory concentration: 7030 nM
Compound 4: the middle estimate sits 1.3-fold (0.11 log units) below what was measured; low and high end bracket the measured number.
By their numbers in this assay, from the lowest: compounds 1, 3, 4 and 2 (each within the scatter of the next, the first and the last beyond it).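

In this assay, the first five-membered aromatic ring with 1 hetero atom on this carbonyl carbon, thiophen-2-yl, does not separate from any of the substituted phenyl groups (the steps read a 1.2-fold higher number from compound 3 to compound 4 (0.06 log units; within the scatter) and a 1.3-fold lower number from compound 2 to compound 4 (0.12 log units; within the scatter) and a 1.6-fold higher number from compound 1 to compound 4 (0.20 log units; within the scatter)). Compound 4 therefore shows that a change of ring size and the loss of a ring substituent, taken together, give no step beyond the scatter at this position. Nothing available explains this result.

Still open, going by these compounds, is whether furan-2-yl, cyclohexyl or a short alkyl chain on the same carbonyl carbon would give a step beyond the scatter. Also open, on these data alone, is whether a carboxylic acid or a dimethylamino group on the phenyl ring would do so.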